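The compounds below may be only part of what the source reports. "The series", "measured", "known", "first", "only" and "open" are said of these compounds alone.

Compound 1 `COc1ccc(/C=C/C(=O)/C=C/c2ccc(OCc3cn(CCCCOc4cc(=O)oc5ccccc45)nn3)c(OC)c2)cc1OC`: 59%
Compound 2 `COc1ccc(/C=C/C(=O)/C=C/c2ccc(OCc3cn(CCCCCOc4cc(=O)oc5ccccc45)nn3)c(OC)c2)cc1OC`: 47%
Compound 3 `COc1cccc(/C=C/C(=O)/C=C/c2ccc(OCc3cn(CCCCCOc4cc(=O)oc5ccccc45)nn3)c(OC)c2)c1`: 37%

Of the compounds shown here, three have so far been tested in a functional assay on THP-1 cells (Homo sapiens) for inhibition, read by sulforhodamine B assay, with a stated time of 48 h, tested at 50 uM; a higher number here means more inhibition of growth at the concentration tested, a lower number less inhibition of growth. Compound 1 gives 59%, the highest of the three, with its gaps to both other compounds beyond the scatter. Compound 2 gives 47%, and compound 3 gives 37%. Compound 1 and compound 2 share most of their structure, but the difference between their two cores is not broken down here. Compound 2 and compound 3 differ in one place only: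

hydrogen in place of methoxy on an aromatic carbon

In this assay this change produced a step of a number 10 percentage points lower from compound 2 to compound 3 (within the scatter), a shift that does not exceed the usual variation of repeated measurements.

Compound 4 `COc1cccc(/C=C/C(=O)/C=C/c2ccc(OCc3cn(CCCCOc4cc(=O)oc5ccccc45)nn3)c(OC)c2)c1` has not yet been measured. It stands to compound 1 exactly as compound 3 stands to compound 2:

hydrogen in place of methoxy on an aromatic carbon

The surroundings of the altered position read the same in both cases, so this is the same change, now carried out on the core of compound 1 rather than that of compound 2. The expectation for compound 4 rests on compound 1 with its value of 59% and on the single earlier occurrence of this change, the step of a number 10 percentage points lower from compound 2 to compound 3 (within the scatter). On that basis compound 4 is expected to show a step of a number 10 percentage points lower from compound 1 to compound 4 (within the scatter). Compound 4 is accordingly estimated at 49%, with a likely range from 36% to 62%.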

Compound 4, percent growth inhibition at one concentration: 47%
Estimate against measurement, compound 4: 2 percentage points above; low and high end bracket the measured number.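

In this assay, exchanging methoxy for hydrogen, which turns 3,4-dimethoxyphenyl into 3-methoxyphenyl, gave a number 12 percentage points lower from compound 1 to compound 4 (beyond the scatter), and the same change on the two cores gave steps that cannot be told apart: the same change on two cores in this assay, a number 10 percentage points lower (within the scatter) from compound 2 to compound 3 and a number 12 percentage points lower (beyond the scatter) from compound 1 to compound 4, 2 percentage points apart, within the scatter of two such steps The change therefore carried over from the core of compound 2 to the core of compound 1 with its direction and size preserved, and the fact that one step is printed as within the scatter and the other as beyond it marks no real difference between them, since both sit close to that boundary. Going by these compounds alone, this agreement rests on only two pairs of compounds, in one assay and at one concentration, so it does not show that the step would hold on other cores, and it says nothing about why the methoxy group matters to growth inhibition.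

The compounds shown leave open what a hydroxyl group, a chlorine atom or an amine would do in place of that methoxy group. They also leave open whether the step would keep its size on a core with a longer chain.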